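Acetylating the hydrazone: an expectation for compound 4

The source may report more compounds than this note shows. Statements on the series, on what has been measured and on what is new or still open speak of the compounds shown alone.

Measured compounds:
Compound 1, `COc1ccc(/C(=N\O)c2ccc3c(ccn3C)c2)c(OC)c1OC`: 270 nM
Compound 2, `COc1ccc(/C(=N\OC(C)=O)c2ccc3c(ccn3C)c2)c(OC)c1OC`: 1500 nM
Compound 3, `COc1ccc(/C(=N\N)c2ccc3c(ccn3C)c2)c(OC)c1OC`: 2000 nM

All three share one core and differ only in the group on the double-bonded nitrogen. In a functional assay on HT-29 cells (Homo sapiens) for cytotoxicity, read by XTT assay, with a stated time of 72 h (on this read-out lower numbers stand for stronger inhibition and higher numbers for weaker inhibition), compound 3 gives the highest number of the three. Its nearest neighbour is compound 2, a 1.3-fold higher number from compound 2 to compound 3 (0.12 log units; within the scatter), so these two cannot be told apart. Its furthest neighbour is compound 1, a 7.4-fold higher number from compound 1 to compound 3 (0.87 log units; beyond the scatter).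

Compound 4, `COc1ccc(/C(=N\NC(C)=O)c2ccc3c(ccn3C)c2)c(OC)c1OC`, is not yet measured. It arises from compound 3 by acetyl in place of hydrogen on an amine nitrogen. The closest parallel is the step in which the oxygen of compound 1 received the same acetyl group: a 5.6-fold higher number from compound 1 to compound 2 (0.74 log units; beyond the scatter). That step was modest but clearly beyond the scatter, pointing toward a weaker compound. Compound 3 already sits close to compound 2 in this assay. The acetyl on nitrogen is expected to shift the number only modestly upward, and a result within the scatter would not be surprising.

The expected step is a 1.8-fold higher number from compound 3 to compound 4 (0.24 log units; within the scatter). Compound 4 is therefore estimated at 3500 nM, with a plausible range from 1200 nM to 10000 nM.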

Compound 4, half-maximal inhibitory concentration: 2000 nM
The estimate for compound 4 lay 1.8-fold (0.24 log units) above the measured number; measured number inside the range.
By their numbers in this assay, from the lowest: compound 1; then compounds 2, 3 and 4 (each within the scatter of the next).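

In this assay the acetyl on the amine nitrogen of compound 3 makes no readable difference (no change at the digits printed from compound 3 to compound 4 (within the scatter)), unlike the same acetyl on the oxygen (a 5.6-fold higher number from compound 1 to compound 2 (0.74 log units; beyond the scatter)), so one change gave two different outcomes at this position, depending on the atom that carries it. Acetamido and acetoxy on the double-bonded nitrogen also cannot be told apart (a 1.3-fold higher number from compound 2 to compound 4 (0.12 log units; within the scatter)), while the hydroxy group keeps the lowest number of the series (a 7.4-fold higher number from compound 1 to compound 4 (0.87 log units; beyond the scatter)). Nothing available offers a reason for the difference between the two acetyl steps.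

Still open, going by these compounds, is whether a methyl group or a longer chain on the amine nitrogen would also leave the number unchanged. Also open, on these data alone, is whether a methoxy group in place of the hydroxy would stay close to compound 1.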